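The Same Small Change on a Stronger Core

A few compounds are considered here, and "the series" means these few. Any claim that something is new, unique, unknown or untested is made for them only; others in the source may bear on it.

Four compounds built on one shared core are compared here. Compound 1 is `COc1cc2c(Oc3ccc(NC(=O)c4nn(-c5ccccc5C)c(=O)cc4C)cc3F)ccnc2cc1OCCCN1CCCCC1`, and in a functional assay on MKN-45 cells (Homo sapiens) for inhibition, read by MTT assay, with a stated time of 72 h (on this read-out higher numbers stand for weaker inhibition and lower numbers for stronger inhibition), compound 1 gives 1310 nM. Compound 2 is `COc1cc2c(Oc3ccc(NC(=O)c4nn(-c5ccccc5C)c(=O)cc4C)cc3F)ccnc2cc1OCCCN1CCC(C)CC1`; in this assay compound 2 gives 1290 nM. The change from compound 1 to compound 2 is methyl in place of hydrogen on a saturated ring carbon, and it made a step of a 1.0-fold lower number from compound 1 to compound 2 (0.01 log units; within the scatter). Compound 3 is `COc1cc2c(Oc3ccc(NC(=O)c4nn(-c5ccccc5OC(F)(F)F)c(=O)cc4C)cc3F)ccnc2cc1OCCCN1CCCCC1`; it differs from compound 1 by trifluoromethoxy in place of methyl on an aromatic carbon, and in this assay compound 3 gives 40 nM. That step, a 33-fold lower number from compound 1 to compound 3 (1.52 log units; beyond the scatter), is the large one in this set, and compound 3 stands with the lowest number of the three measured compounds, its gaps to compound 1 and to compound 2 both beyond the scatter.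

Compound 4 is `COc1cc2c(Oc3ccc(NC(=O)c4nn(-c5ccccc5OC(F)(F)F)c(=O)cc4C)cc3F)ccnc2cc1OCCCN1CCC(C)CC1` and has not yet been measured. It differs from compound 3 by methyl in place of hydrogen on a saturated ring carbon, which is the same change as that from compound 1 to compound 2, made at the same place on the core of compound 3 rather than on that of compound 1. Going by the values given here, the only guide to what it will do is the earlier step of a 1.0-fold lower number from compound 1 to compound 2 (0.01 log units; within the scatter), which lay within the scatter. On that basis the step from compound 3 to compound 4 in this assay is expected to be about no change at the digits printed from compound 3 to compound 4 (within the scatter), so compound 4 is expected to stay close to compound 3. For compound 4 the estimated value in this assay is 40 nM, with a likely range from 20 nM to 80 nM.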

Compound 4, half-maximal inhibitory concentration: 70 nM
Beside the measured number, compound 4's estimate is 1.8-fold (0.24 log units) below it; low and high end bracket the measured number.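

In this assay, putting the methyl on the piperidine ring of the stronger core, which turns piperidin-1-yl into 4-methylpiperidin-1-yl, gave a 1.8-fold higher number from compound 3 to compound 4 (0.24 log units; within the scatter), so this change stayed within the scatter on both cores: the same change on two cores in this assay, a 1.0-fold lower number (0.01 log units; within the scatter) from compound 1 to compound 2 and a 1.8-fold higher number (0.24 log units; within the scatter) from compound 3 to compound 4, 1.8-fold (0.25 log units) apart, within the scatter of two such steps. The other change, trifluoromethoxy in place of methyl on an aromatic carbon, also carried over, giving an 18-fold lower number from compound 2 to compound 4 (1.27 log units; beyond the scatter) with the 4-methylpiperidin-1-yl group in place, a large step much like the one seen with plain piperidin-1-yl: the same change on two cores in this assay, a 33-fold lower number (1.52 log units; beyond the scatter) from compound 1 to compound 3 and an 18-fold lower number (1.27 log units; beyond the scatter) from compound 2 to compound 4, 1.8-fold (0.25 log units) apart, within the scatter of two such steps. Within these four compounds, then, the two changes add up as if each ignored the other, but this rests on one set of four compounds in one assay, and it does not show that the methyl would be just as quiet on any other core in the series.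

The compounds shown leave open what a larger or different group at that ring carbon would do, such as an ethyl, a hydroxyl or a dimethylamino group, or a morpholine in place of the piperidine ring. They also leave open whether a chlorine or a trifluoromethyl group in place of the trifluoromethoxy group would give a step of similar size.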